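Replacing the Ring on the Side Chain of Compound 3

A few compounds are considered here, and "the series" means these few. Any claim that something is new, unique, unknown or untested is made for them only; others in the source may bear on it.

Measured compounds and their numbers:
compound 1 `CC(C)C(c1noc(=O)[nH]1)c1ccc(-c2ccc3cccc(F)c3c2)[nH]c1=O` 41 nM
compound 2 `CC(C)C(c1ccc(-c2ccc3cccc(F)c3c2)[nH]c1=O)N1CCCCS1(=O)=O` 122 nM
compound 3 `CC(C)C(Cc1noc(=O)[nH]1)c1ccc(-c2ccc3cccc(F)c3c2)[nH]c1=O` 70 nM

All three share one core and differ only in the group carried on the side chain. In a functional assay on CHO cells for antagonist activity at prostaglandin E2 receptor EP3 subtype (Homo sapiens), read by cAMP accumulation (on this read-out lower numbers stand for stronger inhibition and higher numbers for weaker inhibition), compound 3 stands second highest of the three numbers. Its gap to compound 1, a 1.7-fold higher number from compound 1 to compound 3 (0.23 log units; within the scatter), lies within the scatter, as does its gap to compound 2, a 1.7-fold lower number from compound 2 to compound 3 (0.24 log units; within the scatter). Within the data shown here, the only step beyond the scatter is a 3.0-fold higher number from compound 1 to compound 2 (0.47 log units; beyond the scatter), a modest weakening when the aromatic ring is exchanged for the six-membered non-aromatic ring.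

Compound 4 `CC(C)C(Cc1nnc[nH]1)c1ccc(-c2ccc3cccc(F)c3c2)[nH]c1=O` keeps the chain of compound 3 and changes the ring at its end: a group of 5 heavy atoms (2 carbon, 3 nitrogen; one five-membered aromatic ring with 3 hetero atoms) in place of a group of 6 heavy atoms (2 carbon, 2 nitrogen, 2 oxygen; one five-membered aromatic ring with 3 hetero atoms), on a saturated chain carbon, two bonds along the chain from an aromatic carbon

Among the measured compounds shown here, no measured step swaps one five-membered aromatic ring for another, so the expectation rests on the modest size of a 3.0-fold higher number from compound 1 to compound 2 (0.47 log units; beyond the scatter) and the small size of a 1.7-fold higher number from compound 1 to compound 3 (0.23 log units; within the scatter). A change of this kind at this position is therefore expected to give a small to modest weakening, a 2.1-fold higher number from compound 3 to compound 4 (0.33 log units; beyond the scatter). Compound 4 is expected to give about 150 nM, with a range from 50 nM to 450 nM.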

Compound 4, half-maximal inhibitory concentration in the prostaglandin E2 receptor EP3 subtype assay: 17 nM
Compound 4: the middle estimate sits 8.8-fold (0.95 log units) above what was measured; the measured number lies below the stated range.
By their numbers in the prostaglandin E2 receptor EP3 subtype assay, from the lowest: compound 4; then compounds 1, 3 and 2 (each within the scatter of the next, the first and the last beyond it).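

In the prostaglandin E2 receptor EP3 subtype assay, the 4H-1,2,4-triazol-3-yl ring at the end of the chain gives a clear gain over the ring it replaces (a 4.1-fold lower number from compound 3 to compound 4 (0.61 log units; beyond the scatter)), so exchanging one five-membered aromatic ring for another matters at this position. Compound 4 also stands apart from the other two compounds (a 2.4-fold lower number from compound 1 to compound 4 (0.38 log units; beyond the scatter); a 7.2-fold lower number from compound 2 to compound 4 (0.86 log units; beyond the scatter)), which gives it the lowest number of the four. In a physicochemical assay for solubility, in phosphate buffer, measured as kinetic solubility (a higher number here means a more soluble compound, a lower number a less soluble compound), compound 3 gives 30400 nM and compound 4 gives 24200 nM (a 1.3-fold lower number from compound 3 to compound 4 (0.10 log units; within the scatter)), so the gain comes with no shift beyond the scatter on this read-out.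

Nothing available here explains the gain. As far as these compounds go, whether a tetrazole ring, a carboxylic acid or an amine at the end of the same chain would hold it remains open.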